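The compounds below may be only part of what the source reports. "The series", "measured", "known", "first", "only" and "open" are said of these compounds alone.

Compound 1 `COc1ccc(C(N)=O)cc1/C=C/c1ccccc1C`: 11000 nM
Compound 2 `COc1ccccc1/C=C/c1cc(C(N)=O)ccc1OC`: > 50000 nM
Compound 3 `COc1ccc(C(N)=O)cc1/C=C/c1ccccc1OC(F)(F)F`: 36000 nM

In an ADME assay on HCT-116 cells (Homo sapiens) for antiproliferative activity (on this read-out lower numbers stand for stronger inhibition and higher numbers for weaker inhibition), compound 3 gives 36000 nM, the higher of the two true numbers in this small set. Compound 1 is its nearest neighbour on the scale. Compound 2 gives only a limit, > 50000 nM.

The next compound, compound 4 `COc1ccc(C(N)=O)cc1/C=C/c1ccccc1Cl`, has chloro in place of trifluoromethoxy on an aromatic carbon. For the measured compounds named here, no chloro compound has been measured yet, so the closest guide comes from the steps at this same place. With methyl as the starting group, trifluoromethoxy gave a 3.3-fold higher number from compound 1 to compound 3 (0.51 log units; beyond the scatter) and methoxy gave an at least 4.5-fold higher number from compound 1 to compound 2 (0.65 log units; beyond the scatter). Both changes are modest in size, and both raise the number.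

Going by the values given here, compound 1, the only one here whose group holds no oxygen, gives 11000 nM, and chloro holds no oxygen either. A move back toward that value therefore seems likely. The expected change is a 2.4-fold lower number from compound 3 to compound 4 (0.38 log units; beyond the scatter). The estimate for compound 4 is 15000 nM, with an expected range from 5000 nM to 40000 nM.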

Compound 4, half-maximal inhibitory concentration: > 50000 nM
Compound 4: a limit, no number (the forecaster's own chance of this, stated with the estimate: 10%); middle value at least 3.3-fold (0.52 log units) away from the limit.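

In this assay compound 4 gives only a limit, > 50000 nM, and not a true number. Chloro holds no oxygen, yet replacing methyl with it gives an at least 4.5-fold higher number from compound 1 to compound 4 (0.65 log units; beyond the scatter), so lacking oxygen is not enough to keep the number low at this position, and all three replacements of methyl shown here raise it. Replacing trifluoromethoxy with chloro gives an at least 1.3-fold higher number from compound 3 to compound 4 (0.14 log units; that floor lies within the scatter), so this floor does not clearly separate the two groups, and the step between compound 2 and compound 4 cannot be read.

The true numbers of compound 2 and compound 4 stay hidden, which leaves the order of methoxy, chloro and trifluoromethoxy open: the limit of > 50000 nM in this assay, at which 2 of the 4 values shown sit. On these data alone, it is also open whether an ethyl group or an amine at this place would stay close to compound 1, at 11000 nM.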